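A few compounds are considered here, and "the series" means these few. Any claim that something is new, unique, unknown or untested is made for them only; others in the source may bear on it.

Three compounds built on one shared core have been examined in a functional assay on CHO-K1 cells for antagonist activity at C-X-C chemokine receptor type 3 (Homo sapiens), read by FLIPR and calcium flux; on this read-out lower numbers stand for stronger inhibition and higher numbers for weaker inhibition. Compound 1, `CC1CN(S(=O)(=O)C[C@]23CC[C@H](CC2=O)C3(C)C)CCN1c1ccc(C(F)(F)F)cn1`, gives 316 nM. Compound 2, `CC1CN(c2ccc(C(F)(F)F)cn2)CCN1S(=O)(=O)C[C@]12CC[C@H](CC1=O)C2(C)C`, gives 631 nM in this assay. Compound 3, `CC1(C)[C@@H]2CC[C@@]1(CS(=O)(=O)N1CCN(c3ccc([N+](=O)[O-])cn3)CC1)C(=O)C2`, reaches only the limit of the assay in this assay, reported as > 31600 nM. Going by the values given here, compound 3 thus stands at the weak end of these numbers, as the one value of the three that is a limit rather than a number (the limit of > 31600 nM in this assay, at which 1 of the 3 values shown sits).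

Compound 4, `CC1(C)[C@@H]2CC[C@@]1(CS(=O)(=O)N1CCN(c3ncc(Br)cn3)CC1)C(=O)C2`, differs from compound 3 in a single place: 5-bromopyrimidin-2-yl in place of 5-nitropyridin-2-yl on an amine nitrogen in a ring. Among the compounds with values here, no measured pair shows this exchange, and compound 1 and compound 2 differ from compound 4 in more than one place. The expected step of an at least 1.5-fold lower number from compound 3 to compound 4 (0.19 log units; that floor lies within the scatter) is small, within the scatter or a little beyond it, with compound 4 remaining weak. Compound 4 is estimated at 20000 nM in this assay, with a range from 3000 nM to 100000 nM, and a limit rather than a number is a real possibility.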

Compound 4, half-maximal inhibitory concentration: 631 nM
Compound 4: middle estimate off by 32-fold (1.50 log units), on the high side; the whole stated range lies above it.
By their numbers in this assay, from the lowest: compounds 1, 2 and 4 (each within the scatter of the next). At a limit, above all of these: compound 3.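

In this assay, putting 5-bromopyrimidin-2-yl in place of 5-nitropyridin-2-yl on an amine nitrogen in a ring gives an at least 50-fold lower number from compound 3 to compound 4 (1.69 log units; beyond the scatter). Going by these compounds alone, this single exchange is the first to show that the group at this place can, on its own, separate a measurable value from a limit on the shared core, since no earlier pair of compounds isolated a change here. Compound 3 stands at a limit, so the step gives only a floor and its full size stays unknown: the limit of > 31600 nM in this assay, at which 1 of the 4 values shown sits.

Going by these compounds, what remains open is whether the change in the ring or the change in its substituent carries the step, since the exchange alters both at once. A 5-bromopyridin-2-yl or a 5-nitropyrimidin-2-yl group at the same place would separate the two, and a chlorine or a nitrile in place of the bromine would test how specific the bromine is.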